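The source may report more compounds than this note shows. Statements on the series, on what has been measured and on what is new or still open speak of the compounds shown alone.

In a functional assay on DU-145 cells (Homo sapiens) for cytotoxicity, read by MTT assay (a lower number here means a stronger inhibitor, a higher number a weaker inhibitor), three compounds have been measured: compound 1 `CC(C)=CC[C@@H](OC(=O)C1CCOC1)C1=CC(=O)c2c(O)ccc(O)c2C1=O` gives 47500 nM, compound 2 `CCC(CO[C@H](CC=C(C)C)C1=CC(=O)c2c(O)ccc(O)c2C1=O)OC(C)=O` gives 25400 nM, and compound 3 `COCCO[C@H](CC=C(C)C)C1=CC(=O)c2c(O)ccc(O)c2C1=O` gives 43200 nM.

Compound 1 has the highest of the three numbers, yet neither neighbour stands apart from it: a 1.9-fold lower number from compound 1 to compound 2 (0.27 log units; within the scatter) and a 1.1-fold lower number from compound 1 to compound 3 (0.04 log units; within the scatter). Compound 4 `CC(C)=CC[C@@H](OC(=O)CC(O)c1ccccc1)C1=CC(=O)c2c(O)ccc(O)c2C1=O` differs from compound 1 in one place: 2-hydroxy-2-phenylethyl in place of oxolan-3-yl on a carbonyl carbon. The steps from compound 1 to compound 2 and to compound 3 are the ones that bear on this, since each also rebuilds the group hanging from that same oxygen, and both stayed within the scatter. No step beyond the scatter is therefore expected for compound 4. Compound 4 is estimated at 38000 nM, between 15000 nM and 90000 nM, which is expected to mean a 1.3-fold lower number from compound 1 to compound 4 (0.10 log units; within the scatter).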

Compound 4, half-maximal inhibitory concentration: 17000 nM
The estimate for compound 4 lay 2.2-fold (0.35 log units) above the measured number; low and high end bracket the measured number.
By their numbers in this assay, from the lowest: compounds 4, 2, 3 and 1 (each within the scatter of the next, the first and the last beyond it).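

Placing 2-hydroxy-2-phenylethyl instead of oxolan-3-yl on the carbonyl carbon gives the only step in this assay so far that leaves the scatter: a 2.8-fold lower number from compound 1 to compound 4 (0.45 log units; beyond the scatter). The earlier changes to the group on that same oxygen stayed within the scatter, so this site can show a modest shift in the number after all. No measurement here explains the shift.

The entering group adds both a phenyl ring and a hydroxyl, and the compounds shown cannot tell which one matters. A plain 2-phenylethyl group, or an amine in place of the hydroxyl, would separate the two.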